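The source may report more compounds than this note shows. Statements on the series, on what has been measured and on what is new or still open speak of the compounds shown alone.

Three compounds of the series carry a number in a functional assay on Caco-2 cells (Homo sapiens), read by fluorescence, tested at 10 uM; on this read-out lower numbers stand for a stronger effect and higher numbers for a weaker effect at the one concentration tested. Compound 1 `COc1cc(/C=C/C(=O)/C=C(/C=C/c2ccc(OC(C)=O)c(OC)c2)NC2CCCCC2)ccc1OC(C)=O` gives 62%. Compound 2 `CCC(C)NC(=C\C(=O)/C=C/c1ccc(O)c(OC)c1)/C=C/c1ccc(O)c(OC)c1` gives 66%. Compound 3 `CCC(C)NC(=C\C(=O)/C=C/c1ccc(OC(C)=O)c(OC)c1)/C=C/c1ccc(OC(C)=O)c(OC)c1` gives 86%. Among the measured compounds shown here, the one measured step between compounds that differ in a single place is a number 24 percentage points higher from compound 1 to compound 3 (beyond the scatter). Compound 2 sits second highest of the three numbers, though its gap to compound 1 lies within the scatter, while compound 3 stands beyond the scatter above it.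

Compound 4 `CCCCNC(=C\C(=O)/C=C/c1ccc(O)c(OC)c1)/C=C/c1ccc(O)c(OC)c1` is not yet measured in this assay. It differs from compound 2 by butyl in place of sec-butyl on an amine nitrogen. For the measured compounds named here, the only measured step at an amine nitrogen, a number 24 percentage points higher from compound 1 to compound 3 (beyond the scatter), exchanges a cyclohexyl for a sec-butyl and does so on the core of compound 1 rather than that of compound 2, so it bears on the present change only loosely. Nothing measured separates butyl from sec-butyl on this nitrogen. No step beyond the scatter is therefore expected for compound 4 in this assay. The expected step is no change at the digits printed from compound 2 to compound 4 (within the scatter). Compound 4 is estimated at 66%, within a range from 50% to 82%.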

Compound 4, a percentage reported as activity, at one concentration (the size of the read-out at that concentration, not a potency): 83%
Compound 4: middle estimate off by 17 percentage points, on the low side; measured number outside the range, above it.
By their numbers in this assay, from the lowest: compounds 1 and 2 (each within the scatter of the next); then compounds 4 and 3 (each within the scatter of the next).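

In this assay, butyl in place of sec-butyl on an amine nitrogen gives a number 17 percentage points higher from compound 2 to compound 4 (beyond the scatter), so this position responds to how the chain is joined, even though the group that leaves and the group that enters have the same heavy atoms. The nitrogen substituent now has a second step beyond the scatter, alongside a number 24 percentage points higher from compound 1 to compound 3 (beyond the scatter) on a different core, and both point towards a weaker effect at the one concentration tested. No measurement at hand accounts for the size or direction of the new step.

The compounds shown leave open whether a tert-butyl or a longer chain such as hexyl on this nitrogen would track with butyl or with sec-butyl. On these data alone, it also remains open whether butyl in place of sec-butyl gives a similar step on the core of compound 3.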